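Swapping 3-chlorophenyl for 4-iodophenyl: compound 3 to compound 4

The source may report more compounds than this note shows. Statements on the series, on what has been measured and on what is new or still open speak of the compounds shown alone.

In a functional assay on HeLa cells (Homo sapiens) for antiproliferative activity, read by MTT assay, with a stated time of 48 h (a lower number here means a stronger inhibitor, a higher number a weaker inhibitor), compound 1 `Oc1ccc2ccccc2c1C(Nc1nc2ccc(Cl)cc2s1)c1cn(-c2ccccc2)nc1-c1ccc(F)cc1` gives 30100 nM and compound 2 `COc1cccc(-c2nn(-c3ccccc3)cc2C(Nc2nc3ccc(Cl)cc3s2)c2c(O)ccc3ccccc23)c1` gives 30000 nM while compound 3 `Oc1ccc2ccccc2c1C(Nc1nc2ccc(Cl)cc2s1)c1cn(-c2ccccc2)nc1-c1cccc(Cl)c1` gives 18300 nM so compound 3 stands within the scatter of both others. Compound 4 `Oc1ccc2ccccc2c1C(Nc1nc2ccc(Cl)cc2s1)c1cn(-c2ccccc2)nc1-c1ccc(I)cc1` follows from compound 3 through the change 4-iodophenyl in place of 3-chlorophenyl on an aromatic carbon which puts 4-iodophenyl in place of 3-chlorophenyl on an aromatic carbon of a five-membered aromatic ring with 2 nitrogen. Three measured exchanges at this aryl group bear on it: a 1.6-fold lower number from compound 1 to compound 3 (0.22 log units; within the scatter) and a 1.0-fold lower number from compound 1 to compound 2 (0.00 log units; within the scatter) and a 1.6-fold lower number from compound 2 to compound 3 (0.21 log units; within the scatter) all stay within the scatter. Among the compounds with values here, no measured compound carries iodine. No step beyond the scatter is therefore expected in this assay here. The estimated change is a 1.2-fold higher number from compound 3 to compound 4 (0.08 log units; within the scatter) and is expected to stay within the scatter. Compound 4 is expected at 22000 nM with an estimated range of 10000 nM to 42000 nM on repeated measurement.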

Compound 4, half-maximal inhibitory concentration: 12100 nM
Compound 4: the middle estimate sits 1.8-fold (0.26 log units) above what was measured; low and high end bracket the measured number.
By their numbers in this assay, from the lowest: compounds 4, 3, 2 and 1 (each within the scatter of the next, the first and the last beyond it).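

In this assay, within the data shown here, the 4-iodophenyl group brings the first steps beyond the scatter at this aryl position, both modest: a 2.5-fold lower number from compound 2 to compound 4 (0.39 log units; beyond the scatter) and a 2.5-fold lower number from compound 1 to compound 4 (0.40 log units; beyond the scatter) while a 1.5-fold lower number from compound 3 to compound 4 (0.18 log units; within the scatter) stays within the scatter. Compound 3 and compound 4 therefore cannot be ordered, so the exchanges at this aromatic carbon remain small in size. Nothing at hand explains these steps. Open in this assay is whether an amine or a carboxylic acid on this aryl group, or a longer chain in its place, would shift the number further.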